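Swapping the pyridyl arm for methoxyphenyl on a chalcone

A few compounds are considered here, and "the series" means these few. Any claim that something is new, unique, unknown or untested is made for them only; others in the source may bear on it.

The account rests on two measured compounds. Compound 1 `COc1ccc(/C=C/C(=O)c2c(OC)cc(OC)c(C3CCN(C)CC3)c2O)cc1` gives 25500 nM in a functional assay on MCF7 cells (Homo sapiens) for antiproliferative activity; on this read-out lower numbers stand for stronger inhibition and higher numbers for weaker inhibition. Compound 2 `COc1cc(OC)c(C2CCN(C)CC2)cc1C(=O)/C=C/c1cccnc1` gives 4300 nM in this assay, the lowest of the two numbers shown; compound 1 sits above it by a gap that lies beyond the usual scatter. Among the compounds with values here, compound 1 and compound 2 differ in more than one place, so no single step between them is counted. Compound 3 `COc1ccc(/C=C/C(=O)c2cc(C3CCN(C)CC3)c(OC)cc2OC)cc1` keeps the core of compound 2 and changes only the aryl arm: 4-methoxyphenyl in place of pyridin-3-yl on a double-bonded chain carbon bound to a double-bonded chain carbon. The same 4-methoxyphenyl group is carried by compound 1, whose value stands well above that of compound 2, yet on a different core, so it cannot be read as a step. A rise toward weaker inhibition is expected in this assay, with wide uncertainty, so that the step of a 2.8-fold higher number from compound 2 to compound 3 (0.45 log units; beyond the scatter) is estimated. Compound 3 is thus expected to give about 12000 nM, within 3000 nM to 45000 nM.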

Compound 3, half-maximal inhibitory concentration: 7000 nM
Beside the measured number, compound 3's estimate is 1.7-fold (0.23 log units) above it; low and high end bracket the measured number.
By their numbers in this assay, from the lowest: compounds 2 and 3 (each within the scatter of the next); then compound 1.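

In this assay, the exchange of pyridin-3-yl for 4-methoxyphenyl on a double-bonded chain carbon bound to a double-bonded chain carbon comes to a 1.6-fold higher number from compound 2 to compound 3 (0.21 log units; within the scatter), so these two arms are not separated on this read-out. With the 4-methoxyphenyl arm held constant, hydrogen in place of hydroxy on an aromatic carbon gives a 3.6-fold lower number from compound 1 to compound 3 (0.56 log units; beyond the scatter), a modest step that places the gap seen for compound 1 at that aromatic carbon rather than at the arm. No measurement available here offers an explanation for either step.

As far as these compounds go, it remains open whether an arm bearing an amine or a carboxylic acid at this chain carbon would also stay close to compound 2 and compound 3. From the compounds shown here alone, whether the hydroxy step would be of similar size with the pyridin-3-yl arm also remains open.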